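Chain Length and Cytotoxicity in One Quinazoline Ester Series

A few compounds are considered here, and "the series" means these few. Any claim that something is new, unique, unknown or untested is made for them only; others in the source may bear on it.

Measured compounds:
compound 1, `CCCCCCCCCCCOC(=O)CCC(=O)N1CCN(CCCOc2cc3c(Nc4ccc(F)c(Cl)c4)ncnc3cc2OC)CC1`, gives 2.8% in a functional assay on A549 cells (Homo sapiens) for cytotoxicity, read by MTT assay, with a stated time of 24 h, tested at 80 uM; a higher number here means a weaker effect of the compound at the concentration tested, a lower number a stronger effect.
compound 2, `CCCCCCCCCCCCOC(=O)CCC(=O)N1CCN(CCCOc2cc3c(Nc4ccc(F)c(Cl)c4)ncnc3cc2OC)CC1`, gives 2.3% in this assay.
compound 3, `CCCCCCCCCCCCCCCCCCOC(=O)CCC(=O)N1CCN(CCCOc2cc3c(Nc4ccc(F)c(Cl)c4)ncnc3cc2OC)CC1`, gives 86.7% in this assay.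

The three measured compounds share one core and differ only in the length of the saturated chain attached through the ester. Compound 2 differs from compound 1 by methyl in place of hydrogen on a saturated chain carbon, ten or more bonds along the chain from an oxygen next to a carbonyl group, and that step gave a number 0.5 percentage points lower from compound 1 to compound 2 (within the scatter). The core of compound 3 differs from that of compound 1 by heptyl in place of hydrogen on a saturated chain carbon, ten or more bonds along the chain from an oxygen next to a carbonyl group; the step to it was a number 83.9 percentage points higher from compound 1 to compound 3 (beyond the scatter), and from compound 2 it was a number 84.4 percentage points higher from compound 2 to compound 3 (beyond the scatter). Compound 3 therefore stands highest of the three, with both steps toward it beyond the scatter, meaning the weakest effect at the concentration tested.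

Compound 4, `CCCCCCCCCCCCCCCCCCCOC(=O)CCC(=O)N1CCN(CCCOc2cc3c(Nc4ccc(F)c(Cl)c4)ncnc3cc2OC)CC1`, has not yet been measured in this assay. Among the measured compounds shown here, it differs from compound 3 by methyl in place of hydrogen on a saturated chain carbon, ten or more bonds along the chain from an oxygen next to a carbonyl group, the same change as the one from compound 1 to compound 2, at a place described in the same words. When this change was made once before, the result was a number 0.5 percentage points lower from compound 1 to compound 2 (within the scatter), a step within the scatter. An equally small step is expected here, a number 1.3 percentage points higher from compound 3 to compound 4 (within the scatter), resting on that earlier step and on compound 3 already giving 86.7%. For the measured compounds named here, with only one prior example of the change, the expectation remains loose. Compound 4 is estimated at 88% in this assay, expected to fall between 72% and 100%.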

Compound 4, a percentage reported as activity, at one concentration (the size of the read-out at that concentration, not a potency): 88.4%
Compound 4: the middle estimate sits 0.4 percentage points below what was measured; the measured number falls inside the stated range.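

The added methyl carried over from one core to the next in this assay, with a number 1.7 percentage points higher from compound 3 to compound 4 (within the scatter), and the two methyl steps agree: the same change on two cores in this assay, a number 0.5 percentage points lower (within the scatter) from compound 1 to compound 2 and a number 1.7 percentage points higher (within the scatter) from compound 3 to compound 4, 2.2 percentage points apart, within the scatter of two such steps. The larger extensions carried over as well, with a number 86.1 percentage points higher from compound 2 to compound 4 (beyond the scatter) and, from the shorter chain, a number 85.6 percentage points higher from compound 1 to compound 4 (beyond the scatter), and the heptyl change gave matching results on its two cores: the same change on two cores in this assay, a number 83.9 percentage points higher (beyond the scatter) from compound 1 to compound 3 and a number 86.1 percentage points higher (beyond the scatter) from compound 2 to compound 4, 2.2 percentage points apart, within the scatter of two such steps. Across these four compounds, then, the methyl change stays small on both the shorter and the longer chains, and the heptyl change stays large, but each rests on only two pairs, and this does not show that either would hold on other cores or why the large step appears.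

The compounds shown leave open where along the chain lengths from compound 2 to compound 3 the number moves from the low values to the high values, and whether that move is sudden or gradual. They also leave open how this assay would respond to a branched chain, or to a chain carrying an amine or a carboxylic acid, in place of the saturated chains seen here.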